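The source may report more compounds than this note shows. Statements on the series, on what has been measured and on what is new or still open speak of the compounds shown alone.

Compound 1 `CC(C)(C)Cc1c(-c2cccc(F)c2F)sc(N)c1C(=O)c1ccc(Cl)cc1` was tested in an assay on CHO cells for displacement of a labelled ligand from adenosine receptor A1 (Homo sapiens), read by scintillation counting, tested at 10 uM (a lower number here means less inhibition, a higher number more inhibition at the concentration tested (going by the name of the read-out)), and gave 1%. Compound 2 `CC(C)(C)Cc1c(-c2ccccc2)sc(N)c1C(=O)c1ccccc1Cl` gave 1% in this assay, and compound 3 `COc1ccc(-c2sc(N)c(C(=O)c3cccc(Cl)c3)c2CC(C)(C)C)cc1` gave 1%. On these numbers compound 1 stands level with compound 2 and compound 3, and the gaps lie within the scatter of repeat measurements. Compound 4 `Cc1noc(C)c1-c1sc(N)c(C(=O)c2ccc(Cl)cc2)c1CC(C)(C)C` has not yet been measured in this assay. It differs from compound 1 in one place: 3,5-dimethyl-1,2-oxazol-4-yl in place of 2,3-difluorophenyl on an aromatic carbon. Within the data shown here, no pair of measured compounds shows what such a change does here, and with every measured compound at the same low level, no step beyond the scatter is expected for a number 2 percentage points higher from compound 1 to compound 4 (within the scatter). Compound 4 is therefore estimated at 3% in this assay, with a range from 0% to 15%.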

Compound 4, a percentage reported as inhibition, at one concentration (the size of the read-out at that concentration, not a potency): 1%
Compound 4: the middle estimate sits 2 percentage points above what was measured, within the range that was stated.
By their numbers in this assay, from the lowest: compounds 1, 2, 3 and 4 (each within the scatter of the next).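

In this assay, among these compounds, the change to 3,5-dimethyl-1,2-oxazol-4-yl from 2,3-difluorophenyl, on the aromatic carbon next to the ring sulfur, gives no change at the digits printed from compound 1 to compound 4 (within the scatter) and is the only step read at this position. A five-membered aromatic ring with 2 hetero atoms thus leaves the reading at the level seen with the six-membered aromatic ring of carbon only, although at so low a level the step says little about the position. No measured evidence bears on this result. Still open, from the compounds shown here alone, is whether an amine or a carboxylic acid on this carbon would lift the reading from this level.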